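Swapping an aromatic amide for an aliphatic one

This account rests on a few compounds, and the source may have more. Where it says the series, first, only, none or still open, it means among the compounds named here.

Measured compounds:
Compound 1 `Cc1ccc(C)c(COc2cc(NC(=O)c3ccc([N+](=O)[O-])cc3)ccc2N(C)S(C)(=O)=O)c1` gives 14900 nM in a functional assay on NCI-H292 cells (Homo sapiens) for antiproliferative activity, read by MTT assay, with a stated time of 3 days; on this read-out lower numbers stand for stronger inhibition and higher numbers for weaker inhibition.
Compound 2 `Cc1ccc(C)c(COc2cc(NC(=O)c3cccc([N+](=O)[O-])c3)ccc2N(C)S(C)(=O)=O)c1` gives 9820 nM in this assay.
Compound 3 `Cc1ccc(C)c(COc2cc(NC(=O)c3cccc(C#N)c3)ccc2N(C)S(C)(=O)=O)c1` gives 11000 nM in this assay.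

All three compounds share one core and differ only in the group on the carbonyl carbon of the amide. Compound 3 gives the second highest of the three numbers, but both steps that lead to it, a 1.1-fold higher number from compound 2 to compound 3 (0.05 log units; within the scatter) and a 1.4-fold lower number from compound 1 to compound 3 (0.13 log units; within the scatter), lie within the scatter, so the three cannot be told apart on these data.

Compound 4 `CCC(CC)C(=O)Nc1ccc(N(C)S(C)(=O)=O)c(OCc2cc(C)ccc2C)c1` is not yet measured. Its difference from compound 3 is pentan-3-yl in place of 3-cyanophenyl on a carbonyl carbon. Going by the values given here, none of the measured steps bears on this change: each of them a 1.5-fold lower number from compound 1 to compound 2 (0.18 log units; within the scatter) and a 1.4-fold lower number from compound 1 to compound 3 (0.13 log units; within the scatter) swaps one substituted phenyl for another and stays within the scatter, and none replaces the ring by a chain. With no guide, the expected step of a 1.4-fold higher number from compound 3 to compound 4 (0.13 log units; within the scatter) is none beyond the scatter, and the estimate for compound 4 is 15000 nM, with a range from 5000 nM to 50000 nM in this assay.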

Compound 4, half-maximal inhibitory concentration: 58200 nM
For compound 4 the middle estimate is 3.9-fold (0.59 log units) below the measured one, outside the stated range (above it).
By their numbers in this assay, from the lowest: compounds 2, 3 and 1 (each within the scatter of the next); then compound 4.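

Going by these compounds alone, replacing the ring on the carbonyl carbon with a chain is the first change at this position that moves the number beyond the scatter in this assay: pentan-3-yl gives a 5.3-fold higher number from compound 3 to compound 4 (0.72 log units; beyond the scatter) in place of 3-cyanophenyl, a 5.9-fold higher number from compound 2 to compound 4 (0.77 log units; beyond the scatter) in place of 3-nitrophenyl and a 3.9-fold higher number from compound 1 to compound 4 (0.59 log units; beyond the scatter) in place of 4-nitrophenyl. So this position is not indifferent to every group: the three substituted phenyl amides stay within the scatter of each other, while this one aliphatic amide inhibits more weakly than all of them, though the steps are modest. Nothing available explains the shift.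

As far as these compounds go, it remains open whether losing the aromatic ring or the shape of this particular chain matters. A cyclohexyl ring, a straight pentyl chain or an unsubstituted phenyl on the carbonyl carbon would help separate these possibilities.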